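The source may report more compounds than this note shows. Statements on the series, on what has been measured and on what is new or still open speak of the compounds shown alone.

Of the compounds shown here, two on the shared core have been measured so far, compound 1 `CC(O)(COc1ccccc1C(F)(F)F)C(=O)Nc1cccc(S(F)(F)(F)(F)F)c1` and compound 2 `CC(O)(COc1ccc(C#N)cc1)C(=O)Nc1cccc(S(F)(F)(F)(F)F)c1`. In a functional assay on VCaP cells (Homo sapiens) for antiproliferative activity, read by propidium iodide staining, with a stated time of 96 h (a lower number here means a stronger inhibitor, a higher number a weaker inhibitor), compound 1 gives 36700 nM and compound 2 gives 26600 nM. Compound 2 holds the lower of the two numbers, but the gap between them lies within the scatter, so the pair cannot be ranked.

Compound 3 `CC(O)(COc1ccc(C#N)cc1C(F)(F)F)C(=O)Nc1cccc(S(F)(F)(F)(F)F)c1` is compound 2 with one addition, trifluoromethyl in place of hydrogen on an aromatic carbon, ortho to a large group and meta to a cyano group. It therefore carries the trifluoromethyl group of compound 1 together with the cyano group of compound 2.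

Going by the values given here, only one measured step bears on this, a 1.4-fold lower number from compound 1 to compound 2 (0.14 log units; within the scatter). That step exchanges one aromatic group for another, and no measurement shows the addition of trifluoromethyl on its own. Because a 1.4-fold lower number from compound 1 to compound 2 (0.14 log units; within the scatter) stays within the scatter, no change beyond the scatter is expected in this assay, in either direction. The expected step is a 1.2-fold lower number from compound 2 to compound 3 (0.08 log units; within the scatter). For compound 3 the estimated value is 22000 nM, with an expected range from 9000 nM to 50000 nM.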

Compound 3, half-maximal inhibitory concentration: 30600 nM
Beside the measured number, compound 3's estimate is 1.4-fold (0.14 log units) below it; measured number inside the range.
By their numbers in this assay, from the lowest: compounds 2, 3 and 1 (each within the scatter of the next).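

In this assay, going by these compounds alone, trifluoromethyl in place of hydrogen on an aromatic carbon, ortho to a large group and meta to a cyano group, gives a 1.2-fold higher number from compound 2 to compound 3 (0.06 log units; within the scatter), the first direct reading of this addition, and it shows no change beyond the scatter. The other single change leading to compound 3, cyano in place of hydrogen on an aromatic carbon, gives a 1.2-fold lower number from compound 1 to compound 3 (0.08 log units; within the scatter), so with either group already on the ring, adding the other leaves the number within the scatter. No measurement is available to explain this result.

From the compounds shown here alone, it remains open whether any substituent on this ring can move the number beyond the scatter, for example an amine or a carboxylic acid in place of the cyano group, and whether trifluoromethyl would read the same at another place on the ring. Also open, going by these compounds, is what a change elsewhere on the shared core would do, such as a longer chain in place of the methyl group on the carbon that carries the hydroxyl group.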